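The compounds below may be only part of what the source reports. "The series", "measured", "known", "first", "only" and "open" are said of these compounds alone.

Two phthalimide esters have been measured in a functional assay on the whole organism for inhibition, with Lepidium sativum as the target, tested at 1 ppm; on this read-out higher numbers stand for more inhibition of growth at the one concentration tested and lower numbers for less inhibition of growth. Compound 1 `CCOC(=O)C(C)CN1C(=O)c2ccccc2C1=O` carries the chain on a carbon attached directly to the imide nitrogen, whereas compound 2 `CCCCCOC(=O)C(C)ON1C(=O)c2ccccc2C1=O` carries it through an oxygen. In this assay compound 1 gives 0%. In this assay compound 2 gives 64%, the higher of the two numbers, and the gap between compound 2 and compound 1 lies beyond the usual scatter; since the two structures differ in more than one place, no single step can be read from them.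

The next compound, compound 3 `COC(=O)C(C)ON1C(=O)c2ccccc2C1=O`, keeps the oxygen-linked arrangement of compound 2 and changes only the ester end: hydrogen in place of butyl on a saturated chain carbon bound to an oxygen next to a carbonyl group. Going by the values given here, no measured pair tells how the length of this chain alone affects the outcome, so the expectation rests on compound 2 alone. A loss of part of the inhibition seems the more likely direction, with the step from compound 2 to compound 3 expected to be a number 24 percentage points lower from compound 2 to compound 3 (beyond the scatter). Compound 3 is therefore estimated at 40% in this assay, within a range from 10% to 70%.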

Compound 3, percent growth inhibition at one concentration: 64%
Beside the measured number, compound 3's estimate is 24 percentage points below it, within the range that was stated.
By their numbers in this assay, from the lowest: compound 1; then compounds 2 and 3 (each within the scatter of the next).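

Replacing butyl with hydrogen on a saturated chain carbon bound to an oxygen next to a carbonyl group, which turns the pentyloxy ester into the methoxy ester, gives no change at the digits printed from compound 2 to compound 3 (within the scatter) in this assay. Going by these compounds alone, this is the first change that can be read at a single place, and it shows that, for this pair, the inhibition of growth at the one concentration tested does not separate a pentyl ester from a methyl ester. Nothing available accounts for this result, and the pair shows only that the two chain ends read alike here, not what lies behind it.

From the compounds shown here alone, it remains open whether a longer chain such as octyl, or a carboxylic acid in place of the ester, would keep the inhibition at this level, and whether compound 2 and compound 3 would still read alike at other concentrations. The role of the oxygen link also stays open, as no pair shown changes that link alone while the ester end stays the same.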